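Three Limits and a Sulfamoyl Carbamoyl Replacement

This account rests on a few compounds, and the source may have more. Where it says the series, first, only, none or still open, it means among the compounds named here.

Measured compounds:
- compound 1 `COC(=O)C1(S(=O)(=O)c2ccc(Oc3ccc(OC(F)(F)F)cc3)cc2)CCC2(CCNCC2)C1`: > 15000 nM
- compound 2 `O=C(OCc1ccccc1)C1(S(=O)(=O)c2ccc(Oc3ccc(OC(F)(F)F)cc3)cc2)CCC2(CCNCC2)C1`: > 15000 nM
- compound 3 `O=C(Nc1ccccn1)C1(S(=O)(=O)c2ccc(Oc3ccc(OC(F)(F)F)cc3)cc2)CCC2(CCNCC2)C1`: > 15000 nM

In a functional assay on blood (Homo sapiens), with a stated time of 60 min, in the presence of a further agent that is not named here (a lower number here means that less compound is needed, a higher number that more compound is needed for the effect), compound 1 gives only a limit, > 15000 nM. Compound 2, with phenyl in place of hydrogen on a saturated chain carbon bound to an oxygen next to a carbonyl group, also gives only a limit, > 15000 nM. Compound 3, with (pyridin-2-yl)amino in place of methoxy on a carbonyl carbon, again gives only a limit, > 15000 nM. The steps among them are therefore a step that the two limits leave unreadable from compound 1 to compound 2, a step that the two limits leave unreadable from compound 1 to compound 3 and a step that the two limits leave unreadable from compound 2 to compound 3; all three values sit at the same point, (the limit of > 15000 nM in this assay, at which 3 of the 3 values shown sit), so nothing about the size or direction of any change at the carbonyl carbon can be read from them.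

Compound 4 `CN(C)S(=O)(=O)NC(=O)C1(S(=O)(=O)c2ccc(Oc3ccc(OC(F)(F)F)cc3)cc2)CCC2(CCNCC2)C1` differs from compound 1 in one place: (dimethylsulfamoyl)amino in place of methoxy on a carbonyl carbon. Both measured changes at this position left the value at the limit, so the data give no readable step to carry over, and compound 4 is expected most probably to sit at the limit as well, with the step from compound 1 estimated as a step that the limit leaves unreadable from compound 1 to compound 4. The estimate for compound 4 in this assay is 20000 nM, within 5000 nM to 60000 nM.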

Compound 4, half-maximal effective concentration: > 15000 nM
Compound 4 ended at the assay's limit; the forecaster's own chance of this, stated with the estimate: 75%; the middle value lies beyond the limit too.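

In this assay compound 4 gives > 15000 nM as a limit and not as a number. Among the compounds shown here, no step from compound 1, compound 2 or compound 3 to compound 4 can be read, because all the values stand at one point: the limit of > 15000 nM in this assay, at which 4 of the 4 values shown sit. The compounds shown leave open whether any change on the carbonyl carbon alters the value, and in which direction.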